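A Larger Bicyclic Amine in Place of Azetidine

A few compounds are considered here, and "the series" means these few. Any claim that something is new, unique, unknown or untested is made for them only; others in the source may bear on it.

Compound 1 `O=C(CCc1ccc(C(F)(F)F)cc1)Nc1ccc2nc(N3CCC3)ccc2c1`: 56 nM
Compound 2 `CC1CCN(c2ccc3cc(NC(=O)CCc4ccc(C(F)(F)F)cc4)ccc3n2)C1`: 400 nM
Compound 3 `O=C(CCc1ccc(C(F)(F)F)cc1)Nc1ccc2nc(N3CC4CC3CO4)ccc2c1`: 70 nM

These three compounds share one core and differ only in the amine on an aromatic carbon. In a functional assay on HEK293 cells for activation of melanin-concentrating hormone receptor 1 (Rattus norvegicus), read by inositol phosphate accumulation (a higher number here means that more compound is needed for the effect, a lower number that less compound is needed), compound 1 gives 56 nM, the lowest of the three numbers; the nearest step is a 1.3-fold higher number from compound 1 to compound 3 (0.10 log units; within the scatter), and the furthest is a 7.1-fold higher number from compound 1 to compound 2 (0.85 log units; beyond the scatter).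

The change to compound 4 `O=C(CCc1ccc(C(F)(F)F)cc1)Nc1ccc2nc(N3CC4CCC3CC4)ccc2c1` is a group of 8 heavy atoms (7 carbon, 1 nitrogen; 2 six-membered non-aromatic rings with 1 hetero atom each) in place of a group of 4 heavy atoms (3 carbon, 1 nitrogen; one four-membered non-aromatic ring with 1 hetero atom), on an aromatic carbon. Among the compounds with values here, two measured steps bear on this. Enlarging the four-membered ring to 3-methylpyrrolidin-1-yl gave a 7.1-fold higher number from compound 1 to compound 2 (0.85 log units; beyond the scatter), a step beyond the scatter. Replacing it with the bridged group of compound 3, which carries one oxygen, gave a 1.3-fold higher number from compound 1 to compound 3 (0.10 log units; within the scatter), within the scatter. Compound 4 carries a still larger group of 8 heavy atoms, built from two six-membered non-aromatic rings and holding no oxygen. Weighing the loss seen in a 7.1-fold higher number from compound 1 to compound 2 (0.85 log units; beyond the scatter) against the tolerance seen in a 1.3-fold higher number from compound 1 to compound 3 (0.10 log units; within the scatter), a modest rise beyond the scatter is expected, a 3.6-fold higher number from compound 1 to compound 4 (0.55 log units; beyond the scatter). Compound 4 is therefore estimated at 200 nM, with a range from 60 nM to 700 nM.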

Compound 4, half-maximal effective concentration: 190 nM
Estimate against measurement, compound 4: 1.1-fold (0.02 log units) above; measured number inside the range.
By their numbers in this assay, from the lowest: compounds 1 and 3 (each within the scatter of the next); then compound 4; then compound 2.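

In this assay, the group of two six-membered rings on this aromatic carbon, next to the ring nitrogen, is not tolerated as the bridged group of compound 3 was: the change gives a 3.4-fold higher number from compound 1 to compound 4 (0.53 log units; beyond the scatter) and, against that oxygen-bearing group, a 2.7-fold higher number from compound 3 to compound 4 (0.43 log units; beyond the scatter). Heavy-atom count alone does not order the numbers at this position, since the larger group still gives a 2.1-fold lower number from compound 2 to compound 4 (0.32 log units; beyond the scatter), and compound 3, which also carries a larger group than compound 2, goes the same way, while compound 1, with the smallest group, stays within the scatter of compound 3. Nothing available accounts for these differences.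

Compounds 3 and 4 differ in both ring size and the oxygen, so the part played by the oxygen cannot be separated from that of the ring framework. The compounds shown also leave open where a plain pyrrolidin-1-yl without the methyl, or morpholin-4-yl, a single six-membered ring holding oxygen, would fall in this series.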